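Cytotoxicity on L6 cells across four related compounds

A few compounds are considered here, and "the series" means these few. Any claim that something is new, unique, unknown or untested is made for them only; others in the source may bear on it.

Compound 1 `O=c1nc(-c2ccccc2)c2cc(-c3ccc(N4CCCC4)nc3)ccc2[nH]1` gives > 50000 nM in an ADME assay on L6 cells (Rattus norvegicus) for cytotoxicity, read by fluorescence and resazurin assay, with a stated time of 72 h (on this read-out lower numbers stand for an effect already at smaller amounts and higher numbers for an effect only at larger amounts of compound), a limit of the assay and not a number.
Compound 2 `O=c1nc(-c2ccccc2)c2cc(-c3ccccc3F)ccc2[nH]1` gives 55800 nM in this assay.
Compound 3 `Cn1ccc(-c2cccc3[nH]c(=O)nc(-c4ccccc4)c23)n1` gives > 50000 nM in this assay, again a limit of the assay.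

Among the compounds with values here, compound 2 thus stands as the only actual number among the three results, the other two being limits. Compound 4 `CN1CCN(c2ccc3[nH]c(=O)nc(-c4ccccc4)c3c2)CC1` has not yet been measured in this assay; it carries 4-methylpiperazin-1-yl in place of 2-fluorophenyl on an aromatic carbon. Within the data shown here, no step between measured compounds is available, and the entering group appears in none of compound 1, compound 2 or compound 3, so the change offers little guidance. Because the limit of > 50000 nM in this assay, at which 2 of the 3 values shown sit, marks where most of the series falls, a result for compound 4 near that limit would not surprise. Compound 4 is expected to show a step of a 1.1-fold higher number from compound 2 to compound 4 (0.03 log units; within the scatter), small against the scatter. The value of compound 4 in this assay is estimated at 60000 nM, within 20000 nM to 150000 nM.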

Compound 4, half-maximal effective concentration: > 50000 nM
Compound 4 ended at the assay's limit; the forecaster's own chance of this, stated with the estimate: 55%; the middle value is on the limit's open side.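

Within the data shown here, compound 4 gives > 50000 nM in this assay, a limit of the assay and not a number, so no step from compound 2 to compound 4 can be read. The compounds shown leave open whether 4-methylpiperazin-1-yl in place of 2-fluorophenyl changes this read-out at all.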